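The compounds below may be only part of what the source reports. "The series", "measured", "known", "first", "only" and "open" are said of these compounds alone.

In an assay on Sf9 cells for inhibition of protein deacetylase HDAC6 (Homo sapiens), read by fluorescence, with a stated time of 2 h; on this read-out lower numbers stand for stronger inhibition and higher numbers for weaker inhibition:
compound 1 `O=C(NO)c1ccc(OCCOc2ccc3cc2COC/C=C/COCc2cccc(c2)-c2ccnc(n2)N3)cc1` gives 66 nM
compound 2 `O=C(NO)c1cccc(NCCOc2ccc3cc2COC/C=C/COCc2cccc(c2)-c2ccnc(n2)N3)c1` gives 2900 nM

Among the compounds with values here, compound 2 holds the highest number of the two measured; the single measured step, a 44-fold higher number from compound 1 to compound 2 (1.64 log units; beyond the scatter), already reaches it from the lower number of compound 1 and is large. Compound 3 `O=C(O)CCCCCCCOc1ccc2cc1COC/C=C/COCc1cccc(c1)-c1ccnc(n1)N2` differs from compound 2 by 5-carboxypentyl in place of (3-(hydroxycarbamoyl)phenyl)amino on a saturated chain carbon, two bonds along the chain from an oxygen on an aromatic ring. Within the data shown here, no measured step touches this change: the one step available, a 44-fold higher number from compound 1 to compound 2 (1.64 log units; beyond the scatter), exchanges one hydroxycarbamoyl-bearing ring for another and still moves the number far, whereas here the whole (3-(hydroxycarbamoyl)phenyl)amino group leaves and a 5-carboxypentyl chain enters, so the step is expected to be larger again and upward in this assay, with a fair chance that only a limit is reported. The estimate for compound 3 is 20000 nM (range 3000 nM to 100000 nM), a step of a 6.9-fold higher number from compound 2 to compound 3 (0.84 log units; beyond the scatter), to be checked against measurement.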

Compound 3, half-maximal inhibitory concentration: 10000 nM
Compound 3: middle estimate off by 2.0-fold (0.30 log units), on the high side; the measured number falls inside the stated range.
By their numbers in this assay, from the lowest: compound 1; then compound 2; then compound 3.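

In this assay, 5-carboxypentyl carries no hydroxycarbamoyl group and no ring, yet it gives only a 3.4-fold higher number from compound 2 to compound 3 (0.54 log units; beyond the scatter), a modest step, while the same group measured against the 4-(hydroxycarbamoyl)phenoxy compound gives a 150-fold higher number from compound 1 to compound 3 (2.18 log units; beyond the scatter), a large one. At this position, then, a hydroxycarbamoyl group does not by itself secure a low number: compound 2 carries one and still stands much nearer to compound 3 than to compound 1. Nothing available accounts for either step.

The hydroxycarbamoyl group and the ring leave together in compound 3, so their shares of these steps stay unseparated. A pentyl chain ending in hydroxycarbamoyl, or a phenoxy group carrying a carboxylic acid, would bear on that question.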